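From a chlorinated four-membered ring to an indanyl group

This account rests on a few compounds, and the source may have more. Where it says the series, first, only, none or still open, it means among the compounds named here.

Of the compounds shown here, three with a shared core have been tested in a functional assay on the whole organism for antagonist activity, with Rattus norvegicus as the target; on this read-out higher numbers stand for an effect only at larger amounts of compound and lower numbers for an effect already at smaller amounts. Compound 1 `c1ccc2c(c1)CC(CCCN1CCN(c3cccc4c3OCCO4)CC1)C2` gives 0.63 mg/kg. Compound 2 `C1=C(CCN2CCN(c3cccc4c3OCCO4)CC2)Cc2ccccc21` gives 0.31 mg/kg. Compound 3 `Clc1cccc2c1CC2CCN1CCN(c2cccc3c2OCCO3)CC1` gives 1.25 mg/kg, the highest of the three numbers; compound 1 lies within the scatter of it, while compound 2 lies beyond the scatter below it, the step being a 4.0-fold higher number from compound 2 to compound 3 (0.61 log units; beyond the scatter).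

Compound 4 `c1ccc2c(c1)CCC2CCN1CCN(c2cccc3c2OCCO3)CC1` has not yet been measured in this assay. Its difference from compound 3 is a group of 9 heavy atoms (9 carbon; one five-membered non-aromatic ring of carbon only, one six-membered aromatic ring of carbon only) in place of a group of 9 heavy atoms (8 carbon, 1 chlorine; one four-membered non-aromatic ring of carbon only, one six-membered aromatic ring of carbon only), on a saturated chain carbon, two bonds along the chain from an amine nitrogen in a ring.

Within the data shown here, the one measured step that bears on this change runs the other way: a 4.0-fold higher number from compound 2 to compound 3 (0.61 log units; beyond the scatter), and compound 4 largely restores the five-membered carbon ring of compound 2, though with that ring saturated rather than unsaturated. Compound 1 also carries a saturated five-membered ring and sits near compound 3, so the reversal may be incomplete. The expected step is therefore a 2.8-fold lower number from compound 3 to compound 4 (0.44 log units; beyond the scatter), a modestly lower number. Compound 4 is estimated at 0.45 mg/kg, with a range from 0.15 mg/kg to 1.3 mg/kg.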

Compound 4, minimum effective dose: 0.63 mg/kg
Beside the measured number, compound 4's estimate is 1.4-fold (0.15 log units) below it; the measured number falls inside the stated range.
By their numbers in this assay, from the lowest: compound 2; then compounds 1, 4 and 3 (each within the scatter of the next).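

Replacing the chlorinated four-membered ring group with 2,3-dihydro-1H-inden-1-yl, on a saturated chain carbon two bonds along the chain from an amine nitrogen in a ring, gives a 2.0-fold lower number from compound 3 to compound 4 (0.30 log units; within the scatter) in this assay, so this change in ring size and chlorine cannot be told apart from repeat-measurement noise. Compound 4 also shows that the two five-membered carbon ring groups are not interchangeable here, since the saturated one gives a 2.0-fold higher number from compound 2 to compound 4 (0.31 log units; beyond the scatter), a modest step just past the scatter. No measurement shown offers an explanation for either step.

On these data alone, the step from compound 3 to compound 4 changes the chlorine and the ring size together, so their separate contributions remain open. Also open, as far as these compounds go, is how a chlorine on the 2,3-dihydro-1H-inden-1-yl group, or a six-membered non-aromatic carbon ring in its place, would read.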